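The compounds below may be only part of what the source reports. "The series", "measured", "known", "first", "only" and "open" are said of these compounds alone.

Measured so far:
Compound 1, `Cc1nnc(SCc2coc3ccccc3c2=O)o1`: 1200 nM
Compound 2, `Cc1ccc2oc(CSc3nnc(N)s3)cc(=O)c2c1`: > 25000 nM
Compound 3, `Nc1nnc(SCc2coc3ccccc3c2=O)s1`: 950 nM

All three were tested in a functional assay on MDA-MB-435S cells (Homo sapiens) for cytotoxicity, read by MTT assay, with a stated time of 72 h; on this read-out higher numbers stand for weaker inhibition and lower numbers for stronger inhibition. Compound 3 gives 950 nM in this assay, and compound 1 gives 1200 nM. These two differ in one place only: 5-methyl-1,3,4-oxadiazol-2-yl in place of 5-amino-1,3,4-thiadiazol-2-yl on a sulfur. That change produces a 1.3-fold higher number from compound 3 to compound 1 (0.10 log units; within the scatter), so the two compounds cannot be told apart on this read-out. Compound 2 has no number in this assay, only a limit, > 25000 nM; this is the limit of > 25000 nM in this assay, at which 1 of the 3 values shown sits. How the core of compound 2 differs from the core of compound 3 is not broken down here.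

Compound 4, `Cc1ccc2oc(CSc3nnc(C)o3)cc(=O)c2c1`, has not yet been measured. It is related to compound 2 by the same change that turns compound 3 into compound 1: 5-methyl-1,3,4-oxadiazol-2-yl in place of 5-amino-1,3,4-thiadiazol-2-yl on a sulfur. The place of the change reads the same in both pairs, so this is the same change. The earlier step, a 1.3-fold higher number from compound 3 to compound 1 (0.10 log units; within the scatter), lay within the scatter, so little shift is expected when that change is carried from compound 2 to compound 4, and because compound 2 sits at the limit of > 25000 nM in this assay, at which 1 of the 3 values shown sits, the most likely outcome for compound 4 is again a limit rather than a number. The step expected from compound 2 to compound 4 is a step that the limit leaves unreadable from compound 2 to compound 4. Compound 4 is therefore expected to give around 30000 nM in this assay, most likely somewhere between 10000 nM and 90000 nM.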

Compound 4, half-maximal inhibitory concentration: > 25000 nM
Compound 4 was reported as a limit; the forecaster's own chance of this, stated with the estimate: 75%; the middle value is on the limit's open side.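

In this assay compound 4 gives only a limit, > 25000 nM, not a number. Compound 2 is also a limit, > 25000 nM. No step from compound 2 to compound 4 can therefore be read, and both compounds sit at the same limit: the limit of > 25000 nM in this assay, at which 2 of the 4 values shown sit. The compounds shown leave open how far 5-methyl-1,3,4-oxadiazol-2-yl in place of 5-amino-1,3,4-thiadiazol-2-yl on a sulfur shifts the value on the core shared by compound 2 and compound 4.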